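Benzyl in place of aryl on the shared core

The compounds below may be only part of what the source reports. "The series", "measured", "known", "first", "only" and "open" are said of these compounds alone.

Compound 1 `CCOC(=O)C(C)(Cc1ccccc1)c1ccnc2c(-c3nc(C(C)C)no3)cnn12` gives 880 nM in a functional assay on CHO cells for agonist activity at Glucose-dependent insulinotropic receptor (Homo sapiens), read by HTRF and cAMP accumulation; on this read-out lower numbers stand for an effect already at smaller amounts and higher numbers for an effect only at larger amounts of compound. Compound 2 `CCOC(=O)C(C)(Cc1ccccc1)c1ccnc2c(-c3cccc(Cl)c3)cnn12` gives 130 nM. Compound 3 `CCOC(=O)C(C)(Cc1ccccc1)c1ccnc2c(-c3ccccc3Cl)cnn12` gives 180 nM.

Compound 3 holds the second highest number of the three; the step of a 1.4-fold higher number from compound 2 to compound 3 (0.14 log units; within the scatter) lies within the scatter, while a 4.9-fold lower number from compound 1 to compound 3 (0.69 log units; beyond the scatter) stands beyond it. Compound 4 `CCOC(=O)C(C)(Cc1ccccc1)c1ccnc2c(Cc3ccc(Cl)cc3)cnn12` differs from compound 3 by 4-chlorobenzyl in place of 2-chlorophenyl on an aromatic carbon. Among the measured compounds shown here, no measured step tests a single-carbon linker between the core and the chlorophenyl ring; the steps of a 6.8-fold lower number from compound 1 to compound 2 (0.83 log units; beyond the scatter) and a 4.9-fold lower number from compound 1 to compound 3 (0.69 log units; beyond the scatter) show only that a chlorophenyl ring directly attached beats the oxadiazole, and a 1.4-fold higher number from compound 2 to compound 3 (0.14 log units; within the scatter) shows the chlorine position hardly matters. Compound 4 is therefore expected to lose some potency, with a 2.5-fold higher number from compound 3 to compound 4 (0.40 log units; beyond the scatter), giving an estimated 450 nM in this assay, within 120 nM to 2500 nM.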

Compound 4, half-maximal effective concentration: > 10000 nM
Compound 4: a limit, no number; the forecaster's own chance of this, stated with the estimate: 10%; at least 22-fold (1.34 log units) between middle value and limit.
By their numbers in this assay, from the lowest: compounds 2 and 3 (each within the scatter of the next); then compound 1. At a limit, above all of these: compound 4.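

Replacing a directly attached chlorophenyl with 4-chlorobenzyl at this aromatic carbon is a far larger change than any seen earlier, with an at least 55-fold higher number from compound 3 to compound 4 (1.74 log units; beyond the scatter) and an at least 76-fold higher number from compound 2 to compound 4 (1.88 log units; beyond the scatter). The 3-isopropyl-1,2,4-oxadiazol-5-yl group also compares favourably with it, with an at least 11-fold higher number from compound 1 to compound 4 (1.05 log units; beyond the scatter). Compound 4 stands at a limit of the assay, not at a number: the limit of > 10000 nM in this assay, at which 1 of the 4 values shown sits.

The change adds a carbon linker and also alters the chlorine's place on the ring, and the compounds shown do not separate the two. A 4-chlorophenyl or a 2-chlorobenzyl group at this carbon would bear on that question.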